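Three Sulfonamides at the Limit, a Fourth Awaiting Measurement

A few compounds are considered here, and "the series" means these few. Any claim that something is new, unique, unknown or untested is made for them only; others in the source may bear on it.

Three compounds share one core and differ only in the group on the sulfonyl sulfur. Compound 1 `O=S(=O)(Nc1ccc(-c2nc3ccccc3o2)cc1)c1cccc(F)c1` carries a 3-fluorophenyl there. In an assay on isolated protein for inhibition of malate dehydrogenase, mitochondrial (Sus scrofa), with stated times of 45 min and 30 min (on this read-out higher numbers stand for weaker inhibition and lower numbers for stronger inhibition), compound 1 gives > 63000 nM, which is a limit of the assay rather than a number. Compound 2 `CS(=O)(=O)Nc1ccc(-c2nc3ccccc3o2)cc1` carries a methyl on the sulfonyl sulfur. In this assay compound 2 gives > 63000 nM, again a limit. Compound 3 `O=S(=O)(Nc1ccc(-c2nc3ccccc3o2)cc1)c1ccccc1O` carries a 2-hydroxyphenyl on the sulfonyl sulfur. In this assay compound 3 gives > 63000 nM, also a limit. Compound 3 therefore stands exactly where the other two stand: the limit of > 63000 nM in this assay, at which 3 of the 3 values shown sit. Since every value is a limit, the steps a step that the two limits leave unreadable from compound 1 to compound 2, a step that the two limits leave unreadable from compound 1 to compound 3 and a step that the two limits leave unreadable from compound 2 to compound 3 cannot be read in size or direction.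

Compound 4 `C=Cc1ccc(S(=O)(=O)Nc2ccc(-c3nc4ccccc4o3)cc2)cc1` is not yet measured and differs from compound 3 in one place: 4-vinylphenyl in place of 2-hydroxyphenyl on a sulfonyl sulfur. The measured steps that bear on this change are the three just named, and none of them is readable. With every measured value sitting at the limit (the limit of > 63000 nM in this assay, at which 3 of the 3 values shown sit), no step beyond the scatter is expected in this assay. Compound 4 is therefore expected to give about 63000 nM, with a range from 20000 nM to 200000 nM. The step of a number no higher from compound 3 to compound 4 (the limit leaves the size open) is expected to be small, and most likely the assay will again report only a limit.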

Compound 4, half-maximal inhibitory concentration: > 63000 nM
Compound 4 gave a limit, no number; the forecaster's own chance of this, stated with the estimate: 75%; the middle value sits exactly at the limit.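

Compound 4, like compound 1, compound 2 and compound 3, gives only a limit, so none of the steps from those three to compound 4 can be read in size or direction: the limit of > 63000 nM in this assay, at which 4 of the 4 values shown sit.

The compounds shown leave open whether any group on the sulfonyl sulfur of the shared core can give an actual number in this assay.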